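The source may report more compounds than this note shows. Statements on the series, on what has been measured and on what is new or still open speak of the compounds shown alone.

Compound 1 `Clc1ccc(C(Oc2ccc3cc(Br)ccc3c2)c2cnc(NCC3CCCCC3)s2)cc1` gives "not toxic" (no number reported) in an ADME assay on HepG2 2.2.15 cells (Homo sapiens) for cytotoxicity; on this read-out higher numbers stand for lower toxicity in this test and lower numbers for higher toxicity in this test.
Compound 2 `COc1ccc(C(=O)Nc2ncc(C(Oc3ccc4cc(Br)ccc4c3)c3ccc(Cl)cc3)s2)cc1` gives > 50000 nM, which is a limit of this assay and not a number.

Both results point the same way: neither compound shows measurable harm to the liver-derived cells within the range tested. Compound 2 sits at the limit of > 50000 nM in this assay, at which 1 of the 2 values shown sits, and compound 1 carries no number at all, so the two cannot be set apart and no size can be given for a gap between them.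

Compound 3 `O=S(=O)(Nc1ncc(C(Oc2ccc3cc(Br)ccc3c2)c2ccc(Cl)cc2)s1)c1ccc(Cl)nc1` has not yet been tested. It keeps the shared core and the bromonaphthalene ether of compound 2, and differs only in one group: (6-chloropyridin-3-yl)sulfonyl in place of (4-methoxyphenyl)carbonyl on a nitrogen on an aromatic ring.

Nothing measured here links this kind of exchange to a shift in cytotoxicity, and the only two reference points are both at the non-toxic end. The step that is expected, a number no higher from compound 2 to compound 3 (the limit leaves the size open), is therefore none beyond the scatter. For compound 3 the estimate in this assay is 50000 nM, with a likely range of 20000 nM to 150000 nM, and a good chance that only a limit is reported again.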

Compound 3, half-maximal cytotoxic concentration: "not toxic" (no number reported)
No number was reported for compound 3; no gap can be computed for the estimate.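

Among these compounds, compound 3 carries no number in this assay, and compound 2 has only a limit there, so no step between compound 2 and compound 3 can be read. The compounds shown leave open how far apart compound 1, compound 2 and compound 3 really lie, and at what concentration, if any, each would harm these cells.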